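The compounds below may be only part of what the source reports. "The series", "measured", "known", "first", "only" and "open" are said of these compounds alone.

In a functional assay on HepG2 cells (Homo sapiens) for inhibition, read by MTT assay, with a stated time of 72 h (on this read-out lower numbers stand for stronger inhibition and higher numbers for weaker inhibition), compound 1, `CN(C(=O)NC(=O)c1ccc(F)c(F)c1)c1nc(C(F)(F)F)c(C(=O)N/N=C/c2ccccc2C(F)(F)F)s1`, gives 10.4 ug/mL. Compound 2, `CN(C(=O)NC(=O)c1ccc(F)c(F)c1)c1nc(C(F)(F)F)c(C(=O)N/N=C/c2cc(C(F)(F)F)cc(C(F)(F)F)c2)s1`, gives 5.47 ug/mL in this assay; the two values sit within the usual scatter of each other, and the difference between the two cores is not broken down here. Compound 3, `CN(C(=O)NC(=O)c1ccc(Cl)cc1Cl)c1nc(C(F)(F)F)c(C(=O)N/N=C/c2cc(C(F)(F)F)cc(C(F)(F)F)c2)s1`, differs from compound 2 at one place. 2,4-dichlorophenyl in place of 3,4-difluorophenyl on a carbonyl carbon In this assay compound 3 gives > 100 ug/mL, which is a limit of the assay rather than a number, (the limit of > 100 ug/mL in this assay, at which 1 of the 3 values shown sits). That single change produced an at least 18-fold higher number from compound 2 to compound 3 (1.26 log units; beyond the scatter), a large loss of activity.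

Compound 4, `CN(C(=O)NC(=O)c1ccc(Cl)cc1Cl)c1nc(C(F)(F)F)c(C(=O)N/N=C/c2ccccc2C(F)(F)F)s1`, has not yet been measured. It differs from compound 1 by the same change at the same place, a carbonyl carbon whose other neighbour is an amide-type nitrogen. 2,4-dichlorophenyl in place of 3,4-difluorophenyl on a carbonyl carbon Because this change gave an at least 18-fold higher number from compound 2 to compound 3 (1.26 log units; beyond the scatter), compound 4 is expected to lose activity to a similar degree. The estimated step is a 9.6-fold higher number from compound 1 to compound 4 (0.98 log units; beyond the scatter). Compound 4 is therefore expected to give about 100 ug/mL, and the assay may well report only a limit for it.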

Compound 4, half-maximal inhibitory concentration: 10.7 ug/mL
For compound 4 the middle estimate is 9.3-fold (0.97 log units) above the measured one; measured number outside the range, below it.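

In this assay, putting 2,4-dichlorophenyl in place of 3,4-difluorophenyl on the core of compound 1 gives a 1.0-fold higher number from compound 1 to compound 4 (0.01 log units; within the scatter), so on this core the change has no visible effect on the read-out. The change therefore does not carry over with one size from one core to the other, and the two steps clearly disagree: the same change on two cores in this assay, an at least 18-fold higher number (1.26 log units; beyond the scatter) from compound 2 to compound 3 and a 1.0-fold higher number (0.01 log units; within the scatter) from compound 1 to compound 4, at least 17-fold (1.24 log units) apart, beyond the scatter of two such steps. Compound 3 gives > 100 ug/mL, which is a limit of the assay and not a number, and two pairs alone cannot show which part of the cores sets the steps apart.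

The compounds shown leave open how a phenyl ring carrying a methoxy group or an amine would behave at this carbonyl carbon, since only the two halogenated rings appear there. As far as these compounds go, it also remains open which of the two steps a further core would follow, for example one with a plain phenyl ring in place of the trifluoromethyl-bearing one.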